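This account rests on a few compounds, and the source may have more. Where it says the series, first, only, none or still open, it means among the compounds named here.

Measured compounds:
compound 1 `O=C1C(Nc2ccc(F)c(F)c2)=CC(=O)c2ncccc21`; in a functional assay on the whole organism (aorta) with Rattus norvegicus as the target (on this read-out higher numbers stand for larger maximal responses and lower numbers for smaller maximal responses), compound 1 gives 92%.
compound 2 `O=C1C(Nc2ccc(F)c(F)c2F)=CC(=O)c2ncccc21`; in this assay compound 2 gives 72%.
compound 3 `O=C1C=C(Nc2ccccc2)C(=O)c2cnccc21`; in this assay compound 3 gives 93%.

The change from compound 1 to compound 2 is fluoro in place of hydrogen on an aromatic carbon and gave a number 20 percentage points lower from compound 1 to compound 2 (beyond the scatter). Compound 3 lies within the scatter of compound 1 and beyond it relative to compound 2; the difference between the core of compound 3 and that of compound 1 is not broken down here.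

Compound 4 `O=C1C=C(Nc2cccc(F)c2)C(=O)c2cnccc21` is still to be measured. It carries fluoro in place of hydrogen on an aromatic carbon, the same kind of change as in compound 2 but not the same: in compound 2 the entering fluoro sits ortho to a fluoro group (1 heavy atom), ortho to a large group and meta to a fluoro group (1 heavy atom), whereas in compound 4 it sits meta to a large group. Among the compounds with values here, the single earlier step, a number 20 percentage points lower from compound 1 to compound 2 (beyond the scatter), comes from another core and another neighbourhood, so it is only a rough guide. A smaller step in this assay is therefore expected, a number 9 percentage points lower from compound 3 to compound 4 (within the scatter). Compound 4 is expected to give 84%, estimated between 66% and 98%.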

Compound 4, largest response reached (Emax), in percent of the reference or control that the assay uses: 89%
Compound 4: the middle estimate sits 5 percentage points below what was measured, within the range that was stated.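

In this assay, fluoro in place of hydrogen on an aromatic carbon does not carry over from one core to the other as a step of fixed size: the same change on two cores in this assay, a number 20 percentage points lower (beyond the scatter) from compound 1 to compound 2 and a number 4 percentage points lower (within the scatter) from compound 3 to compound 4, 16 percentage points apart, beyond the scatter of two such steps

On the core of compound 3 the change gives a number 4 percentage points lower from compound 3 to compound 4 (within the scatter), so no effect of the added fluoro can be read there. This does not show that the core alone sets the size of the step, since the entering fluoro also has different surroundings in the two pairs, and one pair per core gives no general rule.

Open, from the compounds shown here alone, is how chloro, methoxy or an amine would behave in place of this fluoro on either core. Also open, going by these compounds, is whether fluoro at other places on the same ring of compound 4 would stay within the scatter.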